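Isopropylsulfanyl for isobutylamino in the cytotoxicity series

This account rests on a few compounds, and the source may have more. Where it says the series, first, only, none or still open, it means among the compounds named here.

- compound 1 `C=CCOc1nc(N)nc2c1ncn2/C=C1/CC1(CO)CO`: > 300000 nM
- compound 2 `Nc1nc(N2CCCC2)c2ncn(/C=C3/CC3(CO)CO)c2n1`: > 300000 nM
- compound 3 `CC(C)CNc1nc(N)nc2c1ncn2/C=C1/CC1(CO)CO`: > 300000 nM

All three entries are limits of an ADME assay on HFF cells (Homo sapiens) for cytotoxicity, with a stated time of 8 days (on this read-out higher numbers stand for lower toxicity in this test and lower numbers for higher toxicity in this test), not numbers. The series stands at the limit of > 300000 nM in this assay, at which 3 of the 3 values shown sit. Compound 3 gives only the limit > 300000 nM.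

Compound 4 `CC(C)Sc1nc(N)nc2c1ncn2/C=C1/CC1(CO)CO` differs from it as follows: isopropylsulfanyl in place of isobutylamino on an aromatic carbon. Among the measured compounds shown here, the steps that bear on this are a step that the two limits leave unreadable from compound 1 to compound 2, a step that the two limits leave unreadable from compound 1 to compound 3 and a step that the two limits leave unreadable from compound 2 to compound 3. Each swaps the group on the same aromatic carbon, and none has a readable size. Allyloxy, pyrrolidin-1-yl and isobutylamino all reach the limit, so no change beyond the scatter is expected in either direction.

The step expected is a number no higher from compound 3 to compound 4 (the limit leaves the size open). The expected value for compound 4 is 300000 nM, with an estimated range of 120000 nM to 400000 nM.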

Compound 4, half-maximal cytotoxic concentration: > 300000 nM
Compound 4 was reported as a limit; the forecaster's own chance of this, stated with the estimate: 75%; the middle value sits exactly at the limit.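

In this assay, among the compounds shown here, compound 4 gives > 300000 nM, a limit, so no step among compound 1, compound 2, compound 3 and compound 4 can be read. The compounds shown leave open whether these four groups on that aromatic carbon differ at all in this assay.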